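The compounds below may be only part of what the source reports. "The series", "measured", "known", "first", "only" and "open" are said of these compounds alone.

Compound 1, `O=C(Nc1cccnc1)c1ccccc1`, in an assay on V79 cells for inhibition of cytochrome P450 11B1, mitochondrial (Homo sapiens), tested at 500 nM (on this read-out higher numbers stand for more inhibition at the one concentration tested (going by the name of the read-out) and lower numbers for less inhibition), gives 2%.
Compound 2, `O=C(Nc1cccnc1)c1cccc(Cl)c1`, in this assay gives 0%.

Both measured compounds share the same core and both give almost no inhibition at the single concentration tested. Compound 2 carries one chloro group on its benzene ring where compound 1 carries hydrogen, and the step was a number 2 percentage points lower from compound 1 to compound 2 (within the scatter), so the two numbers cannot be told apart and compound 2 stands level with compound 1 rather than below it.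

Compound 3, `O=C(Nc1cccnc1)c1cccc(Cl)c1Cl`, has not yet been measured. It differs from compound 2 in one place: chloro in place of hydrogen on an aromatic carbon.

Among the compounds with values here, only one measured step bears on this change, and it is of the same kind, a swap of hydrogen for a chloro group: a number 2 percentage points lower from compound 1 to compound 2 (within the scatter). That step did not move the read-out beyond the scatter. With nothing else to go on, no step beyond the scatter is expected here either; the step from compound 2 to compound 3 is estimated at a number 2 percentage points higher from compound 2 to compound 3 (within the scatter). For compound 3 the expected value in this assay is therefore 2%, with a range from -8% to 12%.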

Compound 3, a percentage reported as inhibition, at one concentration (the size of the read-out at that concentration, not a potency): 4%
Compound 3: the middle estimate sits 2 percentage points below what was measured; measured number inside the range.
By their numbers in this assay, from the lowest: compounds 2, 1 and 3 (each within the scatter of the next).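

This change puts a chloro group on an aromatic carbon ortho to a chloro group and ortho to a group of 9 heavy atoms, a place the earlier step did not test. In this assay the step is small (a number 4 percentage points higher from compound 2 to compound 3 (within the scatter)), so adding a chloro group here, with one already on the ring, gives no measurable gain or loss of inhibition at the one concentration tested, and this second swap agrees with the first (a number 2 percentage points lower from compound 1 to compound 2 (within the scatter)). No other measurement bears on this result, so the data offer no account of it.

Both chloro steps start from compounds with almost no inhibition, so they say little about how the same swap would act on a compound with a clear read-out. From the compounds shown here alone, what a different group at this place would do, such as an amine, a carboxylic acid or a longer chain, stays open, and so does whether any such group would move the number beyond the scatter.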